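Series notes: fluoro for trifluoromethyl, cytotoxicity outlook

This account rests on a few compounds, and the source may have more. Where it says the series, first, only, none or still open, it means among the compounds named here.

Compound 1 `O=[N+]([O-])c1cn2c(n1)OC[C@@H](OCc1ccc(-c3ccc(OC(F)F)cc3)s1)C2` and compound 2 `O=[N+]([O-])c1cn2c(n1)OC[C@@H](OCc1cc(-c3ccc(C(F)(F)F)cc3)no1)C2` share one core and were run in an ADME assay on Vero cells (Chlorocebus sabaeus) for cytotoxicity, with a stated time of 72 h; on this read-out higher numbers stand for weaker inhibition and lower numbers for stronger inhibition. In this assay compound 1 gives only a limit, > 128000 nM. Compound 2 likewise gives only a limit, > 128000 nM. Compound 2 thus stands at the limit of > 128000 nM in this assay, at which 2 of the 2 values shown sit, and no ordering within the pair can be read. Compound 3 `O=[N+]([O-])c1cn2c(n1)OC[C@@H](OCc1cc(-c3ccc(F)cc3)no1)C2` differs from compound 2 by fluoro in place of trifluoromethyl on an aromatic carbon. Among the compounds with values here, no measured step of this kind exists here, so a step from compound 2 to compound 3 within the scatter, in no set direction, is expected. Compound 3 is expected to give 150000 nM in this assay, within 60000 nM to 400000 nM, most probably again as a limit. The expected step is a step that the limit leaves unreadable from compound 2 to compound 3.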

Compound 3, half-maximal inhibitory concentration: > 128000 nM
Compound 3: only a limit was reported; the forecaster's own chance of this, stated with the estimate: 85%; the middle value lies beyond the limit too.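

Within the data shown here, compound 2 and compound 3 both give only a limit, so no step between them can be read: the limit of > 128000 nM in this assay, at which 3 of the 3 values shown sit.

From the compounds shown here alone, whether fluoro and trifluoromethyl on the aromatic carbon differ at all in this assay stays open.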